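The source may hold more compounds than are shown below. What is called first, only, known or untested is meant among the compounds shown, and "the series" means these compounds.

Within the data shown here, in an in vivo ADME assay on the whole organism (plasma, strain Sprague-Dawley) for pharmacokinetics, with Rattus norvegicus as the target (a higher number here means faster removal of the compound, a lower number slower removal), compound 2 (`O=C1[C@@H](NS(=O)(=O)/C=C/c2ccc(Cl)s2)CCN1c1ccc2c(c1F)CCNC2`) gives 3 mL/min/kg, the lower of the two numbers so far. Compound 1 (`O=C1[C@@H](NS(=O)(=O)c2ccc3c(Cl)c[nH]c3c2)CCN1c1ccc2c(c1)CCNC2`) gives 7.7 mL/min/kg, a gap beyond the usual scatter. Compound 3 (`O=C1[C@@H](NS(=O)(=O)c2ccc3c(Cl)c[nH]c3c2)CCN1c1ccc2c(c1F)CCNC2`) follows from compound 2 by one change on the sulfonyl sulfur: 3-chloro-1H-indol-6-yl in place of 2-(5-chlorothiophen-2-yl)ethenyl on a sulfonyl sulfur. Compound 3 thereby carries the 3-chloro-1H-indol-6-yl group of compound 1, although the two cores are not the same. Among the measured compounds shown here, no measured pair isolates this change, so the expectation rests on only two values. A modest rise in this assay is expected, probably within the scatter. Compound 1 gives 7.7 mL/min/kg. It holds the same group on a different core. The expected step is a 1.6-fold higher number from compound 2 to compound 3 (0.20 log units; within the scatter). For compound 3 the estimated clearance is 4.8 mL/min/kg, with an expected range of 2.2 mL/min/kg to 10 mL/min/kg.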

Compound 3, clearance: 2.7 mL/min/kg
Compound 3: middle estimate off by 1.8-fold (0.25 log units), on the high side; low and high end bracket the measured number.
By their numbers in this assay, from the lowest: compounds 3 and 2 (each within the scatter of the next); then compound 1.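

On the sulfonyl sulfur, this assay does not separate 3-chloro-1H-indol-6-yl from 2-(5-chlorothiophen-2-yl)ethenyl: a 1.1-fold lower number from compound 2 to compound 3 (0.05 log units; within the scatter) and so the two groups, though different in ring count and hydrogen-bond donors, give clearance values within the scatter of each other. Among these compounds, with 3-chloro-1H-indol-6-yl held constant, fluoro in place of hydrogen on an aromatic carbon gives a 2.9-fold lower number from compound 1 to compound 3 (0.46 log units; beyond the scatter) and this is the first comparison that isolates that change. No supporting measurement bears on the reason for either step.

As far as these compounds go, whether the fluoro step carries over to compounds with 2-(5-chlorothiophen-2-yl)ethenyl on the sulfonyl sulfur remains open. Also open, from the compounds shown here alone, is how clearance responds to chloro or methoxy in place of fluoro on that aromatic carbon, or to a plain phenyl on the sulfonyl sulfur.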